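Removing the chloro group from compound 2

A few compounds are considered here, and "the series" means these few. Any claim that something is new, unique, unknown or untested is made for them only; others in the source may bear on it.

In an ADME assay on MT4 cells (Homo sapiens) for cytotoxicity, read by spectrophotometry, with a stated time of 5 days (a lower number here means that less compound is tolerated, a higher number that more compound is tolerated), compound 1 `CONC(=S)N/N=C1\C(=O)N(CN2CCN(c3ccc(Cl)cc3)CC2)c2ccc(C)cc21` gives 300000 nM, compound 2 `Cc1ccc2c(c1)/C(=N/NC(=S)NO)C(=O)N2CN1CCN(c2ccc(Cl)cc2)CC1` gives 335000 nM and compound 3 `O=C1/C(=N\NC(=S)NO)c2cc(F)ccc2N1CN1CCN(c2ccc(Cl)cc2)CC1` gives 194000 nM. Compound 2 therefore stands within the scatter of both compounds to which it is directly linked.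

Compound 4 `Cc1ccc2c(c1)/C(=N/NC(=S)NO)C(=O)N2CN1CCN(c2ccccc2)CC1` differs from compound 2 by hydrogen in place of chloro on an aromatic carbon. This is hydrogen in place of chloro on an aromatic carbon, para to a large group, or 4-chlorophenyl to phenyl.

Within the data shown here, no measured step changes this place, and no measured compound lacks the chloro group, so the available steps bear on the change only indirectly. They are a 1.1-fold higher number from compound 1 to compound 2 (0.05 log units; within the scatter) and a 1.7-fold lower number from compound 2 to compound 3 (0.24 log units; within the scatter), and both stay within the scatter. No step beyond the scatter is therefore expected in this assay. The estimated change is a 1.1-fold lower number from compound 2 to compound 4 (0.03 log units; within the scatter). For compound 4 the expected value is 310000 nM, with an estimated range of 170000 nM to 520000 nM.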

Compound 4, half-maximal cytotoxic concentration: 420000 nM
Estimate against measurement, compound 4: 1.4-fold (0.13 log units) below; the range from low to high includes it.
By their numbers in this assay, from the lowest: compounds 3, 1, 2 and 4 (each within the scatter of the next, the first and the last beyond it).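

In this assay, the change from 4-chlorophenyl to phenyl, on an aromatic carbon para to a large group, gives a 1.3-fold higher number from compound 2 to compound 4 (0.10 log units; within the scatter). Among these compounds, this is the only direct reading of this position, as the earlier steps changed other places. For this pair, the chloro group has no effect that can be separated from the usual scatter, so hydrogen and chloro cannot be told apart here. No measurement shown bears on the reason for this result.

Still open, from the compounds shown here alone, is whether another group at this place, such as methoxy, an amine or a carboxylic acid, would give a step beyond the scatter. Also open, going by these compounds, is whether the same change from 4-chlorophenyl to phenyl reads alike when made on compound 1 or compound 3.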